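The source may hold more compounds than are shown below. What is called first, only, known or untested is meant among the compounds shown, and "the series" means these compounds.

Measured so far:
- compound 1, `O=c1oc2ccc(I)cc2c(=O)n1-c1ccc(F)cc1F`: 15700 nM
- compound 2, `O=c1oc2ccc(I)cc2c(=O)n1-c1ccc(I)cc1F`: 7600 nM

Both numbers come from an ADME assay on RAW264.7 cells (Mus musculus) for cytotoxicity, read by MTT assay, with a stated time of 24 h; a lower number here means that less compound is tolerated, a higher number that more compound is tolerated. Among the compounds with values here, compound 1 stands highest of the two values in this assay; its only neighbour is compound 2, reached by a 2.1-fold lower number from compound 1 to compound 2 (0.32 log units; beyond the scatter), a modest step beyond the scatter, obtained by iodo in place of fluoro on an aromatic carbon of the pendant ring.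

Compound 3, `O=c1oc2ccc(Cl)cc2c(=O)n1-c1ccc(F)cc1F`, is not yet measured. It differs from compound 1 by chloro in place of iodo on an aromatic carbon. Within the data shown here, the change sits on the fused core, not on the pendant ring where the measured step lies, so no measured step bears on it directly. Among the measured compounds shown here, the single step available shows that a halogen swap on the pendant ring moved this assay modestly. For the measured compounds named here, for a halogen swap on the core there is no precedent, and the step expected from compound 1 to compound 3 is therefore set small: a 1.3-fold higher number from compound 1 to compound 3 (0.11 log units; within the scatter), not clearly beyond the scatter, with a wide range in either direction.

Compound 3 is estimated at 20000 nM in this assay, within 9000 nM to 45000 nM.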

Compound 3, half-maximal cytotoxic concentration: 13400 nM
Beside the measured number, compound 3's estimate is 1.5-fold (0.17 log units) above it; the measured number falls inside the stated range.
By their numbers in this assay, from the lowest: compounds 2, 3 and 1 (each within the scatter of the next, the first and the last beyond it).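

In this assay, chloro in place of iodo on an aromatic carbon of the fused system gives a 1.2-fold lower number from compound 1 to compound 3 (0.07 log units; within the scatter), so this read-out does not separate the two halogens at this position of the shared core. Within the data shown here, this is the first reading on the core rather than the pendant ring, and it contrasts with a 2.1-fold lower number from compound 1 to compound 2 (0.32 log units; beyond the scatter), a halogen swap on the pendant ring that lies beyond the scatter, although the two swaps differ in the halogens involved as well as in their place, so the contrast cannot be attributed to place alone. No supporting data are available to explain why compound 1 and compound 3 read alike.

On these data alone, it remains open whether a group other than a halogen at this core position, such as an amine, a carboxylic acid or a methoxy group, would shift the number beyond the scatter in this assay as well. As far as these compounds go, it is also open whether iodo in place of fluoro on the pendant ring would give a similar step with chloro rather than iodo on the core.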